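The source may hold more compounds than are shown below. What is called first, only, known or untested is meant among the compounds shown, and "the series" means these compounds.

In a functional assay on A549 cells (Homo sapiens) for cytotoxicity, read by MTT assay, with a stated time of 4 days (on this read-out lower numbers stand for stronger inhibition and higher numbers for weaker inhibition), compound 1 `COc1cc(C[C@H]2C(=O)OC[C@@H]2Cc2ccc(OC)c(OC)c2)ccc1N` gives 2850 nM. Compound 2 `COc1cc(C[C@H]2C(=O)OC[C@@H]2Cc2ccc(OC)c(OC)c2)ccc1NC(C)=O` reads > 50000 nM, which is a limit and not a number. Compound 3 `COc1ccc(Nc2ccc(C[C@H]3C(=O)OC[C@@H]3Cc3ccc(OC)c(OC)c3)cc2OC)cc1` reads > 50000 nM, again only a limit. The series therefore stands largely at the limit of > 50000 nM in this assay, at which 2 of the 3 values shown sit. Compound 4 `COc1cc(C[C@H]2C(=O)OC[C@@H]2Cc2ccc(OC)c(OC)c2)ccc1Nc1ccc(F)cc1` differs from compound 3 by fluoro in place of methoxy on an aromatic carbon, para to a large group: fluoro in place of methoxy on an aromatic carbon. Among the measured compounds shown here, no measured step covers this exact change. The nearest evidence is on the nitrogen, with an at least 17-fold higher number from compound 1 to compound 2 (1.24 log units; beyond the scatter) and an at least 17-fold higher number from compound 1 to compound 3 (1.24 log units; beyond the scatter), both large. Compound 4 keeps its aryl group on that nitrogen, so it is expected to stay weak in this assay, given an at least 17-fold higher number from compound 1 to compound 3 (1.24 log units; beyond the scatter). The expected change is small, toward a lower number if any: an at least 1.6-fold lower number from compound 3 to compound 4 (0.22 log units; that floor lies within the scatter). For compound 4 the estimate is 30000 nM, with an expected range of 8000 nM to 60000 nM.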

Compound 4, half-maximal inhibitory concentration: > 50000 nM
Compound 4 ended at the assay's limit; the forecaster's own chance of this, stated with the estimate: 55%; middle value at least 1.6-fold (0.22 log units) from the limit.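

In this assay, placing 4-fluorophenyl on the nitrogen of the core of compound 1 gives an at least 17-fold higher number from compound 1 to compound 4 (1.24 log units; beyond the scatter). The loss seen with 4-methoxyphenyl therefore also appears with a second aryl group that carries fluoro in place of methoxy. Compound 4 joins compound 2 and compound 3 at a limit, and the steps among these three cannot be read: the limit of > 50000 nM in this assay, at which 3 of the 4 values shown sit.

As far as these compounds go, whether a methyl group or a longer alkyl chain on this nitrogen returns a readable value stays open. From the compounds shown here alone, whether fluoro and methoxy differ at all in this assay also stays open.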